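Dropping the chloro group from compound 2's benzylidene end

A few compounds are considered here, and "the series" means these few. Any claim that something is new, unique, unknown or untested is made for them only; others in the source may bear on it.

Of the compounds shown here, two have been measured in a functional assay on NCI/ADR-RES cells (Homo sapiens) for antiproliferative activity, read by sulforhodamine B assay, with a stated time of 48 h; on this read-out lower numbers stand for stronger inhibition of growth and higher numbers for weaker inhibition of growth. Compound 1, `COc1ccc(OC)c(/C=C/c2nnc(Nc3ccc(Cl)cc3)o2)c1`, gives 7620 nM in this assay. Compound 2, `COc1ccc(OC)c(/C=C/C(=O)N/N=C/c2ccc(Cl)cc2)c1`, gives 39.1 nM in this assay, the lowest of the two numbers; the gap between compound 1 and compound 2 is far beyond the scatter, so compound 2 is the stronger growth inhibitor of the pair.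

Compound 3, `COc1ccc(OC)c(/C=C/C(=O)N/N=C/c2ccccc2)c1`, differs from compound 2 in one place only: hydrogen in place of chloro on an aromatic carbon, or, read one bond further out, 4-chlorophenyl becoming phenyl. Among the measured compounds shown here, no measured pair shows the effect of this change here, so its size is not known from the data.

The expectation is a modest loss of growth inhibition, a step of a 2.6-fold higher number from compound 2 to compound 3 (0.41 log units; beyond the scatter) from compound 2 to compound 3, small against the large gap between compound 1 and compound 2 and possibly not beyond the scatter. Compound 3 is therefore estimated at 100 nM in this assay, within a range of 30 nM to 400 nM.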

Compound 3, concentration for 50% growth inhibition: 1460 nM
Beside the measured number, compound 3's estimate is 15-fold (1.16 log units) below it; measured number outside the range, above it.
By their numbers in this assay, from the lowest: compound 2; then compound 3; then compound 1.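

In this assay, replacing chloro with hydrogen on this six-membered aromatic ring gives a 37-fold higher number from compound 2 to compound 3 (1.57 log units; beyond the scatter), a large step well beyond the scatter. This single chlorine is therefore no minor detail: in this pair, 4-chlorophenyl and phenyl are far from interchangeable, and the low number of compound 2 depends strongly on the chloro group being present at this place. The data shown contain nothing that explains the size of this step.

So far, only chloro and hydrogen can be compared at this place, so it remains open whether bromo, fluoro, methyl or an amine would keep the growth inhibition seen with compound 2 or lose it as hydrogen does. Compound 1 also carries a 4-chlorophenyl group, but it has no partner with plain phenyl among these compounds, so whether the same change would matter as much on the core of compound 1 also remains open.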